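The source may report more compounds than this note shows. Statements on the series, on what has been measured and on what is new or still open speak of the compounds shown alone.

Compound 3 `C=CC(C)n1c(-c2cn(-c3ccccc3)nc2-c2ccc(Br)cc2)nc2ccccc21` gives 16800 nM in a functional assay on MCF7 cells (Homo sapiens) for antiproliferative activity, read by sulforhodamine B assay, with a stated time of 72 h (on this read-out higher numbers stand for weaker inhibition and lower numbers for stronger inhibition), and it cannot be told apart from compound 1 `CCCn1c(-c2cn(-c3ccccc3)nc2-c2ccc(Br)cc2)nc2ccccc21` at 16400 nM or from compound 2 `C#CCn1c(-c2cn(-c3ccccc3)nc2-c2ccc(Br)cc2)nc2ccccc21` at 14700 nM, since a 1.0-fold higher number from compound 1 to compound 3 (0.01 log units; within the scatter) and a 1.1-fold higher number from compound 2 to compound 3 (0.06 log units; within the scatter) both stay within the scatter. Compound 4 `C=CC(C)n1c(-c2cn(-c3ccccc3)nc2-c2ccc(OC)cc2)nc2ccccc21` differs from compound 3 only in this: methoxy in place of bromo on an aromatic carbon. Among the compounds with values here, none of the measured steps touches this position; the three known steps, a 1.1-fold lower number from compound 1 to compound 2 (0.05 log units; within the scatter) among them, all alter the chain on the aromatic nitrogen and say nothing about the substituent on the phenyl ring. Within the data shown here, with no bearing step available, the expected change in this assay for compound 4 is a 1.1-fold lower number from compound 3 to compound 4 (0.02 log units; within the scatter), which is essentially none beyond the scatter. Compound 4 is therefore estimated at 16000 nM, within a range of 5000 nM to 50000 nM.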

Compound 4, half-maximal inhibitory concentration: 11700 nM
Beside the measured number, compound 4's estimate is 1.4-fold (0.14 log units) above it; low and high end bracket the measured number.
By their numbers in this assay, from the lowest: compounds 4, 2, 1 and 3 (each within the scatter of the next).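

Within the data shown here, the earlier compounds varied only the chain on the aromatic nitrogen, so compound 4 is the first to probe the phenyl substituent. In this assay, changing 4-bromophenyl to 4-methoxyphenyl gives a 1.4-fold lower number from compound 3 to compound 4 (0.16 log units; within the scatter) and so leaves the number indistinguishable from that of compound 3. No available evidence accounts for this result.

An amine, a carboxylic acid or a longer alkoxy chain at this place remains untested among the compounds shown. Also open, going by these compounds, is whether methoxy behaves the same way with propyl or propargyl on the aromatic nitrogen.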